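This account rests on a few compounds, and the source may have more. Where it says the series, first, only, none or still open, it means among the compounds named here.

Compound 1 `COC1CN(C(=O)/C=C/c2ccncc2-c2ccc3ccccc3c2)C1` carries a 3-methoxyazetidin-1-yl group on its amide carbonyl, joined through a double-bonded chain to the shared core. In a functional assay on MDA-MB-231 cells (Homo sapiens) for inhibition, read by sulforhodamine B assay, with a stated time of 72 h (on this read-out higher numbers stand for weaker inhibition of growth and lower numbers for stronger inhibition of growth), compound 1 gives > 10000 nM, and this is a limit of the assay rather than a measured number. Compound 2 `O=C(/C=C/c1ccncc1-c1ccc2cc[nH]c2c1)N1CCOCC1` carries a different amide and a different ring on the same core. In this assay compound 2 gives > 10000 nM, again a limit rather than a number. Compound 1 therefore stands exactly where everything measured so far stands, namely at the limit of > 10000 nM in this assay, at which 2 of the 2 values shown sit. Compound 3 `CN(C)C(=O)/C=C/c1ccncc1-c1ccc2ccccc2c1` is the compound still to be measured. It differs from compound 1 in a single place: dimethylamino in place of 3-methoxyazetidin-1-yl on a carbonyl carbon. Within the data shown here, no step between two measured compounds exists to show what such a change does in this setting. With both known values resting at the limit, the change is expected to produce no step beyond the scatter in either direction. The expected value for compound 3 in this assay is 20000 nM, with a range from 8000 nM to 50000 nM. That estimate means a step that the limit leaves unreadable from compound 1 to compound 3, which is expected to amount to nothing beyond the scatter, with the assay most likely reporting only a limit once more.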

Compound 3, concentration for 50% growth inhibition: 7990 nM
For compound 3 the middle estimate is 2.5-fold (0.40 log units) above the measured one, and the stated range ends above it.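

In this assay, among these compounds, dimethylamino in place of 3-methoxyazetidin-1-yl on a carbonyl carbon gives an at least 1.2-fold lower number from compound 1 to compound 3 (0.09 log units; that floor lies within the scatter) and so provides the first reading of this change, although it cannot establish a real gain in growth inhibition. For compound 1 the figure of > 10000 nM is a limit of the assay and not a number, which leaves the true size of the step unknown and open to being larger than the printed floor. Among the compounds shown here, compound 3 is the first compound here with an actual number, showing that this position on the carbonyl carbon can give a value that is not a limit, while the limit remains the commonest result: the limit of > 10000 nM in this assay, at which 2 of the 3 values shown sit.

The change removes the ring and the methoxy group together, so plain azetidin-1-yl on the same carbonyl carbon would be needed to tell the two apart. On these data alone, whether other amine groups at this place, such as diethylamino or pyrrolidin-1-yl, would carry the value beyond the usual scatter of repeated measurements also remains open.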